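A few compounds are considered here, and "the series" means these few. Any claim that something is new, unique, unknown or untested is made for them only; others in the source may bear on it.

Measured compounds in this series:

Compound 1, `Cc1nsc2c1ncn2[C@H]1C[C@H](O)[C@@H](CO)O1`, in a functional assay on KB cells (Homo sapiens) for antiproliferative activity (on this read-out higher numbers stand for weaker inhibition and lower numbers for stronger inhibition), gives > 100000 nM, which is a limit of this assay and not a number. Compound 2, `CSc1nc2sncc2n1[C@H]1C[C@H](O)[C@@H](CO)O1`, in this assay gives 6000 nM. Compound 3, `Cc1nsc2c1ncn2[C@@H]1O[C@H](CO)[C@@H](O)[C@@H]1O`, in this assay gives > 100000 nM, again a limit of this assay and not a number.

Compound 1 and compound 3 share a core and differ only by hydroxy in place of hydrogen on a saturated ring carbon. The step that the two limits leave unreadable from compound 1 to compound 3 cannot be read in size, since both values sit at the limit of > 100000 nM in this assay, at which 2 of the 3 values shown sit. Compound 2 carries a different core; the difference between the two cores is not broken down here. Among the measured compounds shown here, compound 2 is the only member of the series with a numerical value in this assay.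

Compound 4, `CSc1nc2sncc2n1[C@@H]1O[C@H](CO)[C@@H](O)[C@@H]1O`, is not yet measured. It differs from compound 2 by hydroxy in place of hydrogen on a saturated ring carbon. This is the same kind of change as that from compound 1 to compound 3, though the surroundings are not identical: in compound 1 the position sits next to the ring atom that bears a group of 9 heavy atoms, whereas in compound 2 it sits next to the ring atom that bears a large group.

The measured instance of this change gives no usable size, so the expectation for compound 4 rests on compound 2 at 6000 nM alone, with wide uncertainty. The step from compound 2 to compound 4 is estimated at a 3.3-fold higher number from compound 2 to compound 4 (0.52 log units; beyond the scatter). On that basis compound 4 is expected to give about 20000 nM in this assay, with a plausible range from 3000 nM to 100000 nM.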

Compound 4, half-maximal inhibitory concentration: 15000 nM
Compound 4: the middle estimate sits 1.3-fold (0.12 log units) above what was measured; low and high end bracket the measured number.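

In this assay, hydroxy in place of hydrogen on a saturated ring carbon gives a 2.5-fold higher number from compound 2 to compound 4 (0.40 log units; beyond the scatter), a modest step on the core of compound 2, and compound 4 keeps a numerical value. The same change on the core of compound 1, from compound 1 to compound 3, cannot be read in size, and neither its direction nor its magnitude can be set beside the readable step: the limit of > 100000 nM in this assay, at which 2 of the 4 values shown sit. The series therefore holds a single readable instance of this change, which describes the core of compound 2 only and does not show that the step carries over from one core to the other, whether in size or in direction.

Still open, going by these compounds, is how an amine or a fluorine atom in place of the hydroxy on that saturated ring carbon would compare with hydrogen and with hydroxy on the core of compound 2. Also open, on these data alone, is what a longer chain or a carboxylic acid in place of the hydroxymethyl group would do on that core, and whether either core would then give a number in this assay.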